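Replacing 3-fluorobenzyl with 4-methoxyphenyl: working notes on the series

The compounds below may be only part of what the source reports. "The series", "measured", "known", "first", "only" and "open" are said of these compounds alone.

Measured so far in a functional assay on cells (Neutrophil, Homo sapiens) for activation, read by luminescence, with a stated time of 60 min; on this read-out lower numbers stand for an effect already at smaller amounts and higher numbers for an effect only at larger amounts of compound:
- compound 1 `Cc1cc(Cc2cccc(F)c2)c(=O)n(CC(=O)Nc2ccc(Br)cc2)n1` gives 1900 nM
- compound 2 `COc1cc(Cc2cc(C)nn(CC(=O)Nc3ccc(I)cc3)c2=O)cc(OC)c1` gives 2100 nM
- compound 3 `COc1cccc(C(=O)Nc2cc(C)nn(CC(=O)Nc3ccc(Br)cc3)c2=O)c1` gives 1900 nM

Compound 1 stands level with compound 3 and within the scatter of compound 2, so the three values do not separate. Compound 4 `COc1ccc(-c2cc(C)nn(CC(=O)Nc3ccc(Br)cc3)c2=O)cc1` has not yet been measured. It differs from compound 1 as follows: 4-methoxyphenyl in place of 3-fluorobenzyl on an aromatic carbon with 4-methoxyphenyl in place of 3-fluorobenzyl on an aromatic carbon, opposite the ring nitrogen. Among the measured compounds shown here, no measured pair differs in one place only, so the data do not show the size of any single change. In this assay no step beyond the scatter is expected, and neither direction is favoured. This expectation rests only on compound 3 at 1900 nM and compound 2 at 2100 nM standing within the scatter of compound 1, and the range is kept wide. The expected step is a 1.3-fold higher number from compound 1 to compound 4 (0.10 log units; within the scatter) on this estimate. Compound 4 is estimated at 2400 nM with an expected range from 800 nM to 7500 nM in this read-out.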

Compound 4, half-maximal effective concentration: 2100 nM
For compound 4 the middle estimate is 1.1-fold (0.06 log units) above the measured one, within the range that was stated.
By their numbers in this assay, from the lowest: compounds 1, 3, 2 and 4 (each within the scatter of the next).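

In this assay, among the compounds shown here, 4-methoxyphenyl in place of 3-fluorobenzyl on an aromatic carbon, opposite the ring nitrogen, gives a 1.1-fold higher number from compound 1 to compound 4 (0.04 log units; within the scatter); this is the first comparison that differs in one place only. The position therefore accepts this exchange without a step beyond the scatter, although the entering group counts 1 hydrogen-bond acceptor and the leaving group 0, at 8 heavy atoms each. Nothing available bears on a cause for this result.

On these data alone, whether an amine, a carboxylic acid or a longer chain on this aromatic carbon would give a step beyond the scatter remains open. As far as these compounds go, with this one single-place pair, the size of any change elsewhere on the shared core also remains unknown.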